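Swapping furan for cyanophenyl on a thienopyrimidine antagonist

A few compounds are considered here, and "the series" means these few. Any claim that something is new, unique, unknown or untested is made for them only; others in the source may bear on it.

Of the compounds shown here, three sharing one core have been measured in an assay on CHO-K1 cells for antagonist activity at adenosine receptor A1 (Homo sapiens), read by a beta-galactosidase reporter, with stated times of 15 min and 6 h; on this read-out higher numbers stand for weaker inhibition and lower numbers for stronger inhibition. Compound 1 `CCN(CC)Cc1cc2c(N)nc(-c3ccco3)nc2s1` gives 2130 nM, compound 2 `Nc1nc(-c2ccco2)nc2sc(CN3CCCC3)cc12` gives 6430 nM, and compound 3 `Nc1nc(-c2ccco2)nc2sc(CN3CC=CC3)cc12` gives 290 nM. Compound 3 stands lowest of the three: the step of a 7.3-fold lower number from compound 1 to compound 3 (0.87 log units; beyond the scatter) and the step of a 22-fold lower number from compound 2 to compound 3 (1.35 log units; beyond the scatter) both lie beyond the scatter, while the step of a 3.0-fold higher number from compound 1 to compound 2 (0.48 log units; beyond the scatter) is smaller but also beyond it. All three measured steps concern only the amine carried on the saturated chain carbon; none touches the aromatic group between the two ring nitrogens.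

Compound 4 `N#Cc1ccc(-c2nc(N)c3cc(CN4CC=CC4)sc3n2)cc1` departs from compound 3 exactly there: 4-cyanophenyl in place of furan-2-yl on an aromatic carbon. For the measured compounds named here, no measured step bears on this change, so the record gives no direct guide to its size or direction. The amine part of compound 3, which produced the low number in this assay, is kept unchanged in compound 4. On that basis a modest rise in the number is expected, as the step of a 2.8-fold higher number from compound 3 to compound 4 (0.44 log units; beyond the scatter), with wide uncertainty. Compound 4 is therefore estimated at 800 nM in this assay, within a range from 150 nM to 4000 nM.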

Compound 4, inhibition constant: 2350 nM
Compound 4: middle estimate off by 2.9-fold (0.47 log units), on the low side; measured number inside the range.
By their numbers in this assay, from the lowest: compound 3; then compounds 1 and 4 (each within the scatter of the next); then compound 2.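

For the compounds shown here, the aromatic carbon between two ring nitrogen atoms proves to be a second place where the number moves in this assay, since the earlier steps concerned only the amine: with 4-cyanophenyl in place of furan-2-yl and the amine part unchanged, the record shows an 8.1-fold higher number from compound 3 to compound 4 (0.91 log units; beyond the scatter). The low number of compound 3 therefore does not follow from its amine alone, but holds only for that amine together with furan-2-yl, and this single change in the aromatic group moves the number in the upward direction. Nothing in the record accounts for the rise, which leaves the change described only by its rings, with a six-membered aromatic ring entering where a five-membered aromatic ring leaves.

The compounds shown do not separate the part played by the nitrile from that of the ring carrying it, a question that plain phenyl or thiophen-2-yl at this position would address. They also leave open whether 4-cyanophenyl would shift the number in the same direction and to a similar extent when carried with diethylamino or pyrrolidin-1-yl on the chain carbon.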